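Working notes: from compound 3 to compound 4

The source may hold more compounds than are shown below. What is called first, only, known or untested is meant among the compounds shown, and "the series" means these compounds.

Measured in a functional assay on HCT-116 cells (Homo sapiens) for inhibition, read by CCK-8 assay, with a stated time of 48 h; on this read-out higher numbers stand for weaker inhibition and lower numbers for stronger inhibition:
- compound 1 `COc1ccc(CN(C(=O)CSC(=S)N2CCN(C(=O)OC(C)(C)C)CC2)c2ccc(OC)cc2)cc1`: > 20000 nM (a limit)
- compound 2 `COc1cc(N(Cc2ccc(Cl)cc2)C(=O)CSC(=S)N2CCN(C(=O)OC(C)(C)C)CC2)cc(OC)c1OC`: 8490 nM
- compound 3 `COc1cc(N(Cc2ccc(Br)cc2)C(=O)CSC(=S)N2CCN(C(=O)OC(C)(C)C)CC2)cc(OC)c1OC`: 11400 nM

Within the data shown here, compound 3 stands within the scatter of compound 2, the only other compound with a numerical value. Compound 1 reports only a limit, not a number. Among the measured compounds shown here, the one measured step, a 1.3-fold higher number from compound 2 to compound 3 (0.13 log units; within the scatter), exchanges chloro for bromo on an aromatic carbon.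

Compound 4 `COc1ccc(CN(C(=O)CSC(=S)N2CCN(C(=O)OC(C)(C)C)CC2)c2cc(OC)c(OC)c(OC)c2)cc1OC` is still to be measured. Relative to compound 3, it carries 3,4-dimethoxyphenyl in place of 4-bromophenyl on a saturated chain carbon bound to an amide-type nitrogen. Read one bond further out, this is 3,4-dimethoxybenzyl for 4-bromobenzyl.

For the measured compounds named here, no measured step covers this exchange. The halogen swap is the nearest evidence, and it stayed within the scatter. With only a 1.3-fold higher number from compound 2 to compound 3 (0.13 log units; within the scatter) to go on, no step beyond the scatter is expected in this assay, and no direction is favoured. The expected result is a 1.1-fold lower number from compound 3 to compound 4 (0.06 log units; within the scatter). A result at the limit of > 20000 nM in this assay, at which 1 of the 3 values shown sits, remains possible. For compound 4 the estimate is 10000 nM, with an expected range of 3000 nM to 25000 nM.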

Compound 4, half-maximal inhibitory concentration: > 20000 nM
Compound 4 ended at the assay's limit; the forecaster's own chance of this, stated with the estimate: 25%; at least 2.0-fold (0.30 log units) between middle value and limit.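

Working notes, after compound 4: this position does respond in this assay, although the swap of chloro for bromo gave no step beyond the scatter. With 3,4-dimethoxybenzyl in place of the halogenated benzyl on a saturated chain carbon bound to an amide-type nitrogen, the comparison with the chloro member shows weaker inhibition, with an at least 2.3-fold higher number from compound 2 to compound 4 (0.37 log units; beyond the scatter), while the comparison with the bromo member shows an at least 1.7-fold higher number from compound 3 to compound 4 (0.24 log units; that floor lies within the scatter), so only the first of these two floors clears the scatter and the true size of neither is known. The reading for compound 4 is a limit and not a number, and the series now has a second such reading: the limit of > 20000 nM in this assay, at which 2 of the 4 values shown sit.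

The compounds shown do not separate the loss of the halogen from the arrival of the two methoxy groups, so it remains unclear which of the two goes with the weaker inhibition. Plain unsubstituted benzyl at this place would address that question, and a benzyl carrying an amine or a carboxylic acid would show whether any group here gives stronger inhibition than the halogenated benzyl groups.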